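The compounds below may be only part of what the source reports. "The series", "measured", "known", "first", "only" and "open" are said of these compounds alone.

Measured compounds:
compound 1, `COCCNc1nc(C)cc2c1c(N)nn2C`, in an assay on isolated protein for inhibition of RAC-alpha serine/threonine-protein kinase (Homo sapiens), read by mobility shift assay, tested at 30 uM (a lower number here means less inhibition, a higher number more inhibition at the concentration tested (going by the name of the read-out)), compound 1 gives 6%.
compound 2, `Cc1cc2c(cn1)c(N)nn2C`, in this assay compound 2 gives 0%.

Compound 2 stands at the lowest of the two numbers; its nearest neighbour is compound 1, with a number 6 percentage points lower from compound 1 to compound 2 (within the scatter). Compound 3, `Cc1cc2[nH]nc(N)c2cn1`, differs from compound 2 by hydrogen in place of methyl on an aromatic nitrogen. Within the data shown here, the only measured step concerns a different position and lies within the scatter, so no step is known that bears directly on this change. Compound 3 is therefore expected to show a number 5 percentage points higher from compound 2 to compound 3 (within the scatter). The estimate for compound 3 is 5%, between -5% and 20%.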

Compound 3, a percentage reported as inhibition, at one concentration (the size of the read-out at that concentration, not a potency): -1%
Beside the measured number, compound 3's estimate is 6 percentage points above it, and the stated range covers the measured number.
By their numbers in this assay, from the lowest: compounds 3, 2 and 1 (each within the scatter of the next).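

In this assay, hydrogen in place of methyl on the aromatic nitrogen gives a number 1 percentage points lower from compound 2 to compound 3 (within the scatter), so this position now has a measured step of its own. Compound 2 and compound 3 both read close to no inhibition, so this step cannot show whether the methyl would matter on a compound with a clearly higher number. Nothing measured offers an explanation for this result. The compounds shown leave open whether a longer chain or a benzyl group on this nitrogen would change the number. They also leave open whether the same change would read alike with (2-methoxyethyl)amino present.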